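Nitro substitution on the indole core of a dichlorophenyl aromatase binder

The source may report more compounds than this note shows. Statements on the series, on what has been measured and on what is new or still open speak of the compounds shown alone.

Measured compounds:
compound 1, `C#CCn1c(-c2ccccc2)cc2ccccc21`: 26.3%
compound 2, `Clc1ccc(-c2cc3ccccc3[nH]2)cc1Cl`: 22.7%
compound 3, `Cn1c(-c2ccc(Cl)c(Cl)c2)cc2ccccc21`: 20%

In an assay on isolated protein for inhibition of Aromatase (Homo sapiens), read by fluorescence, using NADPH, with a stated time of 30 min, tested at 50 uM (a lower number here means less inhibition, a higher number more inhibition at the concentration tested (going by the name of the read-out)), compound 2 gives 22.7%, a value within the usual scatter of both compound 1 and compound 3, so the three cannot be ranked. Among the measured compounds shown here, the only single-point step measured, a number 2.7 percentage points lower from compound 2 to compound 3 (within the scatter), stayed within the scatter. Compound 4, `O=[N+]([O-])c1ccc2[nH]c(-c3ccc(Cl)c(Cl)c3)cc2c1`, differs from compound 2 by nitro in place of hydrogen on an aromatic carbon. For the measured compounds named here, no measured step involves a nitro group, so no step bears directly on this change; the one measured step on this core was flat. The expectation is therefore a step of a number 0.3 percentage points higher from compound 2 to compound 4 (within the scatter), none beyond the scatter. Compound 4 is estimated at 23%, between 6% and 42%.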

Compound 4, a percentage reported as inhibition, at one concentration (the size of the read-out at that concentration, not a potency): 7.59%
Beside the measured number, compound 4's estimate is 15.4 percentage points above it; measured number inside the range.
By their numbers in this assay, from the lowest: compound 4; then compounds 3, 2 and 1 (each within the scatter of the next).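

In this assay, nitro in place of hydrogen on an aromatic carbon of the six-membered carbon ring gives a number 15.1 percentage points lower from compound 2 to compound 4 (beyond the scatter). The only earlier step on this core, at the aromatic nitrogen, stayed within the scatter, so this carbon is the first place on the core shown to change the reading beyond it. No measurement shown here accounts for the drop. The compounds shown leave open whether an amine or a nitrile on the same carbon would lower the number too, or whether the drop is particular to nitro.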